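This account rests on a few compounds, and the source may have more. Where it says the series, first, only, none or still open, it means among the compounds named here.

Working notes on the series. Compound 1 `Cc1ccccc1NC(=O)CCC(=O)OCCCCCCSc1ccc([N+](=O)[O-])c2nonc12` is the starting point; in an assay on isolated protein for inhibition of glutathione S-transferase P (Homo sapiens), with a stated time of 10 min (a lower number here means a stronger inhibitor, a higher number a weaker inhibitor), compound 1 gives 4100 nM. Within the data shown here, compound 2 `COc1ccc(NC(=O)CCC(=O)OCCCCCCSc2ccc([N+](=O)[O-])c3nonc23)cc1` carries a 4-methoxyphenyl in place of the 2-methylphenyl on the amide-type nitrogen, and in this assay compound 2 gives 420 nM, the lowest of the two numbers so far; the step of a 9.8-fold lower number from compound 1 to compound 2 (0.99 log units; beyond the scatter) is the only one measured. Compound 3 `COc1ccc(NC(=O)CCC(=O)OCCCCCCSc2ccc([N+](=O)[O-])c3nonc23)cc1OC` differs from compound 2 by methoxy in place of hydrogen on an aromatic carbon, so the change reads 4-methoxyphenyl to 3,4-dimethoxyphenyl. Among the measured compounds shown here, no measured step bears directly on this addition: the single step concerns an exchange of the whole aryl group, not a second methoxy, and it was modest. Little movement beyond the scatter is expected, an estimated step of a 1.1-fold lower number from compound 2 to compound 3 (0.02 log units; within the scatter). For compound 3 in this assay the estimate is 400 nM, within a range from 150 nM to 1200 nM.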

Compound 3, half-maximal inhibitory concentration: 6470 nM
Compound 3: the middle estimate sits 16-fold (1.21 log units) below what was measured; the measured number lies above the stated range.
By their numbers in this assay, from the lowest: compound 2; then compounds 1 and 3 (each within the scatter of the next).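

In this assay, a second methoxy on the aromatic carbon ortho to a methoxy group and meta to a large group is far from a neutral addition: the change from 4-methoxyphenyl to 3,4-dimethoxyphenyl gives a large step (a 15-fold higher number from compound 2 to compound 3 (1.19 log units; beyond the scatter)). The advantage of the 4-methoxyphenyl over the 2-methylphenyl does not survive this addition, since the 3,4-dimethoxyphenyl stands level with the 2-methylphenyl (a 1.6-fold higher number from compound 1 to compound 3 (0.20 log units; within the scatter)). No available evidence bears on this result.

As far as these compounds go, whether the loss belongs to methoxy itself or to any group on this carbon stays open; a fluorine, a methyl or a hydroxyl there, with the 4-methoxy kept, would separate the two. A 3-methoxyphenyl would show whether the 4-methoxy is needed for the effect at all.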